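Sulfonamide series: dimethoxyphenyl in place of methylphenyl

The source may report more compounds than this note shows. Statements on the series, on what has been measured and on what is new or still open speak of the compounds shown alone.

Compound 2 `Cc1ccc(N(Cc2nc3ccccc3[nH]2)S(=O)(=O)c2ccc(C)cc2)cc1` carries a 4-methylphenyl on the sulfonamide nitrogen. In a functional assay on MCF7 cells (Homo sapiens) for inhibition, read by MTT assay, with a stated time of 48 h (on this read-out higher numbers stand for weaker inhibition and lower numbers for stronger inhibition), compound 2 gives only a limit, > 50000 nM, not a number. Its parent compound 1 `Cc1ccc(S(=O)(=O)N(Cc2nc3ccccc3[nH]2)c2ccccc2)cc1` gives 49700 nM in this assay. The step of a number no lower from compound 1 to compound 2 (the limit leaves the size open) cannot be sized because compound 2 sits at the limit of > 50000 nM in this assay, at which 1 of the 2 values shown sits.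

Compound 3 `COc1ccc(N(Cc2nc3ccccc3[nH]2)S(=O)(=O)c2ccc(C)cc2)cc1OC` differs from compound 2 by 3,4-dimethoxyphenyl in place of 4-methylphenyl on a sulfonamide nitrogen. Among the measured compounds shown here, no measured step exchanges one aryl group for another on that nitrogen; the single measured step, methyl for hydrogen on the same ring, left compound 2 at the limit and says nothing readable about the 3,4-dimethoxyphenyl exchange. With both measured compounds at or near the limit, compound 3 is expected to remain in the same weak region, a number no higher from compound 2 to compound 3 (the limit leaves the size open), not beyond the scatter. Compound 3 is therefore estimated at 50000 nM, within 20000 nM to 150000 nM, with a fair chance that this assay again returns only a limit.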

Compound 3, half-maximal inhibitory concentration: > 50000 nM
Compound 3 gave a limit, no number; the forecaster's own chance of this, stated with the estimate: 65%; the middle value lies on the limit itself.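

Compound 3 returns only a limit in this assay, so a second substituted aryl group on the sulfonamide nitrogen, this one with two hydrogen-bond acceptors, also yields no number. Against the phenyl of compound 1, the 3,4-dimethoxyphenyl exchange gives a number no lower from compound 1 to compound 3 (the limit leaves the size open), while the exchange for 4-methylphenyl cannot be read, since compound 2 and compound 3 are both limits. The readout at this position therefore offers almost no resolution, and the aryl exchanges cannot be ranked: the limit of > 50000 nM in this assay, at which 2 of the 3 values shown sit.

Going by these compounds, it remains open whether any group on this aryl ring can bring the series to clearly lower numbers. An amine or a carboxylic acid in place of the methoxy groups would test this, as would a longer chain on the sulfonamide nitrogen in place of the aryl group.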